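Shifting the Bicyclic Amine from Compound 2 to Compound 3

The source may report more compounds than this note shows. Statements on the series, on what has been measured and on what is new or still open speak of the compounds shown alone.

Among the measured compounds shown here, compound 2, `O=C(c1ccc(-c2ccc3c(c2)CNC3)s1)N1N=C(c2cccnc2)CC1c1c(O)cccc1F`, is the higher of the two compounds measured so far in an in vivo ADME assay on the whole organism (strain Sprague-Dawley) for pharmacokinetics, with Rattus norvegicus as the target; a higher number here means that a larger share of the oral dose reaches the circulation, a lower number that a smaller share of the oral dose reaches the circulation: compound 2 gives 37%, while compound 1, `O=C(c1ccc(-c2ccc3c(c2)CNC3)s1)N1N=C(c2cccnc2)CC1c1ccccc1O`, gives 14%. For the measured compounds named here, the only step measured between them, a number 23 percentage points higher from compound 1 to compound 2 (beyond the scatter), concerns a change at a different part of the molecule from the one altered here.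

Compound 3, `O=C(c1ccc(-c2cccc3c2CCNC3)s1)N1N=C(c2cccnc2)CC1c1c(O)cccc1F`, differs from compound 2 by a group of 10 heavy atoms (9 carbon, 1 nitrogen; one six-membered non-aromatic ring with 1 hetero atom, one six-membered aromatic ring of carbon only) in place of a group of 9 heavy atoms (8 carbon, 1 nitrogen; one five-membered non-aromatic ring with 1 hetero atom, one six-membered aromatic ring of carbon only), on an aromatic carbon. Going by the values given here, no measured step bears on this kind of change, since the one known step swapped a hydrogen for a fluoro group and left the bicyclic amine untouched. Without a comparable step, there is no basis to expect a shift in either direction beyond the usual scatter, and the expectation for compound 3 is therefore close to that of compound 2, with a wide range. Compound 3 is thus estimated to give 35% in this assay, between 15% and 60%, an expected change of a number 2 percentage points lower from compound 2 to compound 3 (within the scatter).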

Compound 3, oral bioavailability: 89%
The estimate for compound 3 lay 54 percentage points below the measured number, outside the stated range (above it).
By their numbers in this assay, from the lowest: compound 1; then compound 2; then compound 3.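

In this assay, the group on the aromatic carbon next to the ring sulfur proves to have a strong influence: placing 1,2,3,4-tetrahydroisoquinolin-5-yl there gives a number 52 percentage points higher from compound 2 to compound 3 (beyond the scatter). Until now, the only measured sensitivity lay at a different part of the molecule, in the fluoro step, a number 23 percentage points higher from compound 1 to compound 2 (beyond the scatter), so this result adds a second place where one change moves the number beyond the scatter. The counts of hydrogen-bond donors and acceptors and the net charge are the same for the leaving and entering groups, yet nothing available explains why the larger share of the oral dose reaches the circulation.

The swap changes the non-aromatic ring from five-membered to six-membered and also alters how the bicyclic group is joined to the core, so these compounds cannot show which of the two features matters, or whether both do. On these data alone, it also remains open whether the high number would survive removal of the fluoro group, a methyl group on the ring nitrogen, or replacement of the bicyclic amine by an open-chain aminomethyl group on a six-membered aromatic ring.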